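Propanoyl to acetyl: a one-carbon step on the acyl chain

This account rests on a few compounds, and the source may have more. Where it says the series, first, only, none or still open, it means among the compounds named here.

Measured so far, in a functional assay on ileum for antagonist activity at histamine H1 receptor (Cavia porcellus); on this read-out lower numbers stand for tighter binding and higher numbers for weaker binding:
Compound 1 `N/C(=N\C(=O)CCc1c[nH]c2ccccc12)NCCCc1c[nH]cn1`: 398 nM
Compound 2 `CCC(=O)/N=C(\N)NCCCc1c[nH]cn1`: 5130 nM

Of these two numbers, compound 2 gives the higher one, and the gap to compound 1 lies well beyond the usual scatter, so compound 2 is the weaker of the pair in this assay. The two compounds differ in more than one place, so nothing can be said about which part of the change matters.

Compound 3 `CC(=O)/N=C(\N)NCCCc1c[nH]cn1` is not yet measured. It differs from compound 2 in one spot only: hydrogen in place of methyl on a saturated chain carbon bound to a carbonyl carbon, which is hydrogen in place of methyl on a saturated chain carbon bound to a carbonyl carbon. Within the data shown here, no measured pair shows what such a single carbon does here. A step of this size is expected to stay within the scatter, or at most to weaken binding slightly, giving a 1.3-fold higher number from compound 2 to compound 3 (0.10 log units; within the scatter). Compound 3 is therefore estimated at 6500 nM, with a likely range from 2000 nM to 20000 nM.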

Compound 3, dissociation constant: 8510 nM
Compound 3: middle estimate off by 1.3-fold (0.12 log units), on the low side; the range from low to high includes it.
By their numbers in this assay, from the lowest: compound 1; then compounds 2 and 3 (each within the scatter of the next).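

Among these compounds, this pair is the first in the set that differs in one place only, so the effect of a single carbon on this acyl chain can now be read. In this assay the change from propanoyl to acetyl, hydrogen in place of methyl on a saturated chain carbon bound to a carbonyl carbon, gives a 1.7-fold higher number from compound 2 to compound 3 (0.22 log units; within the scatter) and so does not separate the two compounds: this one carbon makes no difference that the assay can resolve. No measurement here offers an explanation for this result.

Still open, on these data alone, is whether a longer chain such as butanoyl, or an amine or a carboxylic acid at this place, would move the number beyond the scatter. One pair also cannot show whether the same step would behave alike on another core.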